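Chain length between amide and hydroxycarbamoyl group

The source may report more compounds than this note shows. Statements on the series, on what has been measured and on what is new or still open speak of the compounds shown alone.

Three members of the series carry the same core and differ only in the chain that ends in the hydroxycarbamoyl group. Compound 1 `O=C(CCNC(=O)c1cc(-c2ccc(F)cc2)[nH]n1)NO` gives 76000 nM in a functional assay on HepG2 cells (Homo sapiens) for antiproliferative activity, read by MTT assay, with a stated time of 96 h; a lower number here means a stronger inhibitor of growth, a higher number a weaker inhibitor of growth. Compound 2 `O=C(CCCCCCNC(=O)c1cc(-c2ccc(F)cc2)[nH]n1)NO` gives 23200 nM in this assay. From the compounds shown here alone, compound 3 `O=C(CCCCNC(=O)c1cc(-c2ccc(F)cc2)[nH]n1)NO` reaches only the limit of the assay, > 100000 nM, so its true number is unknown. Compound 3 is thus the one member for which only a limit is recorded, and the shown values place it at the weak end, with an at least 4.3-fold higher number from compound 2 to compound 3 (0.63 log units; beyond the scatter) and an at least 1.3-fold higher number from compound 1 to compound 3 (0.11 log units; that floor lies within the scatter).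

Compound 4 `O=C(CCCCCNC(=O)c1cc(-c2ccc(F)cc2)[nH]n1)NO` has not been measured. It differs from compound 3 by (hydroxycarbamoyl)methyl in place of hydroxycarbamoyl on a saturated chain carbon, four bonds along the chain from an amide-type nitrogen. The change bearing on it is the step to compound 2, which carries the same difference cut further out: an at least 4.3-fold higher number from compound 2 to compound 3 (0.63 log units; beyond the scatter) read backwards. The step of a 3.3-fold lower number from compound 1 to compound 2 (0.52 log units; beyond the scatter) points the same way. Compound 4 is therefore expected to sit between compound 3 and compound 2, with the expected step of an at least 2.2-fold lower number from compound 3 to compound 4 (0.34 log units; beyond the scatter). The estimate for compound 4 is 45000 nM, in the range 18000 nM to 100000 nM.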

Compound 4, concentration for 50% growth inhibition: 47600 nM
For compound 4 the middle estimate is 1.1-fold (0.02 log units) below the measured one; the measured number falls inside the stated range.
By their numbers in this assay, from the lowest: compound 2; then compounds 4 and 1 (each within the scatter of the next). At a limit, above all of these: compound 3.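

The value for compound 3 is a limit of the assay and not a number: the limit of > 100000 nM in this assay, at which 1 of the 4 values shown sits. Against that limit, (hydroxycarbamoyl)methyl in place of hydroxycarbamoyl, on a saturated chain carbon four bonds along the chain from an amide-type nitrogen, gives an at least 2.1-fold lower number from compound 3 to compound 4 (0.32 log units; beyond the scatter), so even this change moves the read-out beyond the scatter, though the size of the step remains a floor. Further along the chain there is a 2.1-fold higher number from compound 2 to compound 4 (0.31 log units; beyond the scatter), while a 1.6-fold lower number from compound 1 to compound 4 (0.20 log units; within the scatter) leaves no order to that pair, and compound 1 goes against any steady link between a longer chain and a lower number.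

Open, from the compounds shown here alone, is whether a chain longer than that of compound 2 lowers the number further in this assay. Also open, going by these compounds, is whether a carboxylic acid in place of the hydroxycarbamoyl group keeps any of this growth inhibition.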